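This account rests on a few compounds, and the source may have more. Where it says the series, first, only, none or still open, it means among the compounds named here.

The measured compounds:
Compound 1, `CCN(CC)S(=O)(=O)c1ccc(S(=O)(=O)N2CCC[C@@H](C(=O)NC3CN(C(=O)C4CC4)C3)C2)cc1`: 18500 nM
Compound 2, `CCOC(=O)[C@@H]1CCCN(C(=O)c2ccc(S(=O)(=O)N(CC)CC)cc2)C1`: a limit, > 10000 nM
Compound 3, `CC(C)c1noc(N2CCN(C(=O)[C@@H]3CCCN(S(=O)(=O)c4ccc(S(=O)(=O)NC5CC5)cc4)C3)CC2)n1`: 6700 nM

In a functional assay on BXPC-3 cells (Homo sapiens) for inhibition, read by MTT assay, with a stated time of 7 days (a higher number here means a weaker inhibitor, a lower number a stronger inhibitor), compound 3 gives 6700 nM, the lowest of the two numbers recorded. Compound 1 gives 18500 nM in this assay, and the gap from compound 3 to compound 1 lies beyond the usual scatter. For compound 2, this assay reports only a limit, > 10000 nM, and no number. That limit is the limit of > 10000 nM in this assay, at which 1 of the 3 values shown sits.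

The account follows the change from compound 3 to compound 4, `CC(C)c1noc(N2CCN(C(=O)[C@@H]3CCCN(S(=O)(=O)c4ccc(S(=O)(=O)NC5CCC5)cc4)C3)CC2)n1`, which has not yet been measured in this assay. The change is cyclobutyl in place of cyclopropyl on a sulfonamide nitrogen. Within the data shown here, no measured pair in this set shares that change, so nothing here sets its size; the value of compound 3 in this assay is the only anchor. The expected step is a 1.0-fold lower number from compound 3 to compound 4 (0.01 log units; within the scatter) in this assay, no larger than the scatter in either direction. Compound 4 is therefore estimated at 6500 nM in this assay, with a range from 2500 nM to 16000 nM.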

Compound 4, half-maximal inhibitory concentration: 3300 nM
Compound 4: the middle estimate sits 2.0-fold (0.29 log units) above what was measured, and the stated range covers the measured number.
By their numbers in this assay, from the lowest: compound 4; then compound 3; then compound 1.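

In this assay, the substituent on a sulfonamide nitrogen whose other neighbour is the sulfonyl sulfur turns out to matter: cyclobutyl in place of cyclopropyl gives a 2.0-fold lower number from compound 3 to compound 4 (0.31 log units; beyond the scatter) and this modest step lies beyond the scatter. Among these compounds, it is the first comparison in the set between compounds that differ in one place, and it shows that this position responds to a change as small as moving from a three-membered to a four-membered carbon ring. Nothing measured here gives a reason for the step.

The compounds shown leave open whether the number keeps falling with a larger ring such as cyclopentyl, or whether an open chain such as tert-butyl or a ring carrying an amine would serve equally at this nitrogen. Also open, from the compounds shown here alone, is whether the same change would have a similar effect on a different core, such as that of compound 1.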